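The compounds below may be only part of what the source reports. "The series", "measured", "known", "first", "only" and "open" are said of these compounds alone.

Three compounds have been measured in an ADME assay on MDCK cells (Canis lupus familiaris) for cytotoxicity, read by microscopy, with a stated time of 72 h; on this read-out higher numbers stand for lower toxicity in this test and lower numbers for higher toxicity in this test:

Compound 1 `COC(=O)C[C@H](NC(=O)OC(C)(C)C)C(=O)N(Cc1ccc(F)cc1)C1(C(=O)NCc2ccccc2)CCN(Cc2ccccc2)CC1`: > 100000 nM
Compound 2 `COC(=O)C[C@H](NC(=O)OC(C)(C)C)C(=O)N(Cc1ccc(F)cc1)C1(C(=O)NCc2ccccc2)CCN(C2CCCCC2)CC1`: 73000 nM
Compound 3 `COC(=O)C[C@H](NC(=O)OC(C)(C)C)C(=O)N(Cc1ccc(F)cc1)C1(C(=O)NC(C)(C)C)CCN(Cc2ccccc2)CC1`: 80000 nM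

Compound 1 gives no number of its own in this assay, only a limit, (the limit of > 100000 nM in this assay, at which 1 of the 3 values shown sits). The other two values sit close to that floor: an at least 1.3-fold lower number from compound 1 to compound 2 (0.13 log units; that floor lies within the scatter), and an at least 1.2-fold lower number from compound 1 to compound 3 (0.09 log units; that floor lies within the scatter). Both of those changes touch other parts of the shared core of compound 1 and leave the amine that carries the tert-butoxycarbonyl untouched.

Compound 4 `COC(=O)C[C@H](N)C(=O)N(Cc1ccc(F)cc1)C1(C(=O)NCc2ccccc2)CCN(Cc2ccccc2)CC1` differs from compound 1 at that amine: hydrogen in place of tert-butoxycarbonyl on an amine nitrogen. No measured step alters this position, so nothing shown speaks for a move in either direction, and the two steps that are shown both stay within the scatter. The expectation for compound 4 in this assay is therefore a step of a number no higher from compound 1 to compound 4 (the limit leaves the size open), that is, no change beyond the scatter. Compound 4 is estimated at 100000 nM, with a range from 35000 nM to 300000 nM, and a fair chance that the assay again reports only a limit.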

Compound 4, minimum cytotoxic concentration: 60000 nM
The estimate for compound 4 lay 1.7-fold (0.22 log units) above the measured number; the measured number falls inside the stated range.
By their numbers in this assay, from the lowest: compounds 4, 2 and 3 (each within the scatter of the next). At a limit, above all of these: compound 1.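

Taking off the tert-butoxycarbonyl to leave a free amino group is the only change shown at this amine, and in this assay it gives an at least 1.6-fold lower number from compound 1 to compound 4 (0.22 log units; that floor lies within the scatter). This means that the change at this position, like the two changes elsewhere on the core, shows no step beyond the scatter, at least as far as the floor can be read. Compound 1 has only a limit, so the true size of the step stays unknown: the limit of > 100000 nM in this assay, at which 1 of the 4 values shown sits.

The compounds shown leave open whether a smaller group on this amine nitrogen, such as acetyl or methyl, would read differently from either hydrogen or tert-butoxycarbonyl. They also leave open how the free amino group would read alongside the cyclohexyl of compound 2 or the tert-butyl of compound 3, or with a carboxylic acid in place of the methyl ester.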